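The source may hold more compounds than are shown below. What is called first, only, known or untested is meant among the compounds shown, and "the series" means these compounds.

Compounds measured in a functional assay on HT-29 cells (Homo sapiens) for inhibition, read by MTT assay, with a stated time of 72 h; a higher number here means a weaker inhibitor of growth, a lower number a stronger inhibitor of growth:
Compound 1 `O=S(=O)(NCCNCc1cccc2ccccc12)c1cc(C(F)(F)F)cc(C(F)(F)F)c1` gives 16000 nM.
Compound 2 `O=S(=O)(NCCCNCc1ccc(Cl)c(Cl)c1)c1cc(C(F)(F)F)cc(C(F)(F)F)c1` gives 4700 nM.
Compound 3 `O=S(=O)(NCCCNCC1COc2ccccc2O1)c1cc(C(F)(F)F)cc(C(F)(F)F)c1` gives 2200 nM.

Among these three, compound 3 shows the lowest number and is therefore the strongest growth inhibitor; the step of a 2.1-fold lower number from compound 2 to compound 3 (0.33 log units; beyond the scatter) is modest but beyond the scatter, and compound 1 stands furthest away with a much higher number. Compound 4 `COc1ccccc1CNCCCNS(=O)(=O)c1cc(C(F)(F)F)cc(C(F)(F)F)c1` has not yet been measured in this assay. It differs from compound 3 in a single place: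

2-methoxyphenyl in place of 2,3-dihydro-1,4-benzodioxin-2-yl on a saturated chain carbon bound to an amine nitrogen

For the measured compounds named here, only one measured step bears on a change at this position, namely a 2.1-fold lower number from compound 2 to compound 3 (0.33 log units; beyond the scatter), which shows that swapping the group on the saturated chain carbon bound to the amine nitrogen moves the number by a modest amount. Compound 1 differs in two places at once and so does not isolate this change. With a new aromatic group entering at the same position, a modest step is expected in this assay, most likely toward a somewhat higher number, as a 1.6-fold higher number from compound 3 to compound 4 (0.20 log units; within the scatter). Compound 4 is therefore estimated at 3500 nM, within the range 1500 nM to 8000 nM.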

Compound 4, concentration for 50% growth inhibition: 12000 nM
Estimate against measurement, compound 4: 3.4-fold (0.54 log units) below; measured number above the stated range.
By their numbers in this assay, from the lowest: compound 3; then compound 2; then compounds 4 and 1 (each within the scatter of the next).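

In this assay, for the compounds shown here, this position proves more sensitive than the earlier compounds showed: a 5.5-fold higher number from compound 3 to compound 4 (0.74 log units; beyond the scatter) is a larger move than the only earlier step here, a 2.1-fold lower number from compound 2 to compound 3 (0.33 log units; beyond the scatter). The two groups with a single aromatic ring also differ, as 2-methoxyphenyl in place of 3,4-dichlorophenyl gives a 2.6-fold higher number from compound 2 to compound 4 (0.41 log units; beyond the scatter), so an aromatic ring at this place does not by itself set the number. No measurement at hand explains these differences.

The change removes the non-aromatic ring and one of the two oxygens of the 2,3-dihydro-1,4-benzodioxin-2-yl group together, and the compounds shown cannot separate these two parts. From the compounds shown here alone, how an unsubstituted phenyl or a cyclohexyl group would read at this place also remains open.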